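A few compounds are considered here, and "the series" means these few. Any claim that something is new, unique, unknown or untested is made for them only; others in the source may bear on it.

Compound 2, `O=C(/C=C/CN1CCCC1)Nc1cc2c(N3CCCc4ccccc43)ncnc2cc1O[C@@H]1CCOC1`, gives the lowest of the two numbers available in a functional assay on PC-3 cells (Homo sapiens) for antiproliferative activity, read by MTT assay, with a stated time of 72 h (on this read-out lower numbers stand for stronger inhibition and higher numbers for weaker inhibition), at 5780 nM. For the measured compounds named here, its only neighbour is compound 1, `CC(C)=CC(=O)Nc1cc2c(N3CCCc4ccccc43)ncnc2cc1O[C@@H]1CCOC1`, which in this assay gives 9020 nM. Going by the values given here, the one measured step, a 1.6-fold lower number from compound 1 to compound 2 (0.19 log units; within the scatter), is within the scatter, so the two compounds cannot be ordered against each other.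

Compound 3, `O=C(/C=C/CN1CCCCC1)Nc1cc2c(N3CCCc4ccccc43)ncnc2cc1O[C@@H]1CCOC1`, is the next compound to be measured. It differs from compound 2 by piperidin-1-yl in place of pyrrolidin-1-yl on a saturated chain carbon bound to a double-bonded chain carbon. Among the compounds with values here, no measured step touches this exact change: the step from compound 1 to compound 2 exchanged the whole chain end and stayed within the scatter, which is all the data say about variation at this end of the molecule. The difference between compound 2 and compound 3 is smaller than that, a ring enlarged by one member with the same donor and acceptor count.

Compound 3 is therefore expected to sit close to compound 2 in this assay, with a step of a 1.1-fold lower number from compound 2 to compound 3 (0.02 log units; within the scatter) that is not expected to exceed the scatter. The estimate for compound 3 is 5500 nM, with a range from 2500 nM to 12000 nM.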

Compound 3, half-maximal inhibitory concentration: 3630 nM
Estimate against measurement, compound 3: 1.5-fold (0.18 log units) above, and the stated range covers the measured number.
By their numbers in this assay, from the lowest: compounds 3, 2 and 1 (each within the scatter of the next, the first and the last beyond it).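

In this assay, the exchange of pyrrolidin-1-yl for piperidin-1-yl on a saturated chain carbon bound to a double-bonded chain carbon gives a 1.6-fold lower number from compound 2 to compound 3 (0.20 log units; within the scatter), so compound 2 and compound 3 cannot be ordered against each other, and these two rings are not told apart at this position. For the compounds shown here, the new information lies in the comparison with the open chain end, which gives a 2.5-fold lower number from compound 1 to compound 3 (0.40 log units; beyond the scatter): this modest step is the first at this end of the molecule to pass the scatter, showing stronger inhibition with 3-(piperidin-1-yl)prop-1-en-1-yl than with 2-methylprop-1-en-1-yl on the carbonyl carbon. Nothing available here accounts for that separation.

On these data alone, it remains open whether an open-chain amine such as dimethylamino, or a morpholin-4-yl ring with its added oxygen, would give numbers close to those of compound 2 and compound 3 at this saturated chain carbon, and whether a longer chain between the amine and the double bond would change them. As far as these compounds go, all three values also come from a single cell assay, so whether compound 3 stays apart from compound 1 in other settings is also open.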